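Furan bromination step from compound 2 to compound 4

The source may report more compounds than this note shows. Statements on the series, on what has been measured and on what is new or still open speak of the compounds shown alone.

Measured so far:
compound 1, `N#C/C(=C\c1c[nH]c2ccccc12)C(=O)c1c[nH]c2ccccc12`, 6000 nM
compound 2, `COc1ccc(CNC(=O)/C(C#N)=C/c2ccco2)cc1`, 22000 nM
compound 3, `N#C/C(=C\c1ccco1)C(=O)NCc1ccc(Cl)c(Cl)c1`, 20000 nM

In a functional assay on HT-29 cells (Homo sapiens) for inhibition, read by MTT assay, with a stated time of 72 h (on this read-out higher numbers stand for weaker inhibition of growth and lower numbers for stronger inhibition of growth), compound 2 gives 22000 nM, the highest of the three numbers. Compound 3 gives 20000 nM, which lies within the scatter of compound 2, so no order between these two can be read. Compound 1 gives 6000 nM, lower than compound 2 by a gap beyond the scatter. Compound 2 and compound 3 differ in more than one place, so nothing is drawn from that pair beyond what the two values show.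

Compound 4, `COc1ccc(CNC(=O)/C(C#N)=C/c2cc(Br)co2)cc1`, differs from compound 2 by bromo in place of hydrogen on an aromatic carbon; cut one bond further out, the change reads furan-2-yl to 4-bromofuran-2-yl. Going by the values given here, no pair of measured compounds shows this change, so its size here is unknown. The expected step of a 1.5-fold lower number from compound 2 to compound 4 (0.17 log units; within the scatter) is small, towards a lower number if anything, and likely within the scatter. For compound 4 the estimate in this assay is 15000 nM with a range from 6000 nM to 40000 nM.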

Compound 4, concentration for 50% growth inhibition: 36000 nM
Compound 4: the middle estimate sits 2.4-fold (0.38 log units) below what was measured; measured number inside the range.
By their numbers in this assay, from the lowest: compound 1; then compounds 3, 2 and 4 (each within the scatter of the next).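

Furan-2-yl to 4-bromofuran-2-yl is the only single-place step on hand, and in this assay it gives a 1.6-fold higher number from compound 2 to compound 4 (0.21 log units; within the scatter) on the core of compound 2. The carbon two ring bonds from the ring oxygen therefore takes a bromo in place of hydrogen with no shift in growth inhibition that can be told from the scatter, a reading that rests on this one pair alone. Nothing measured here speaks to why the step is this size.

Open, from the compounds shown here alone, is whether a different group at this carbon, such as an amine, a carboxylic acid or a longer alkyl chain, would move the number beyond the scatter. Also open, going by these compounds, is whether the same bromo step on compound 3 would give a comparable result.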